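The source may hold more compounds than are shown below. What is called first, only, known or untested is meant among the compounds shown, and "the series" means these compounds.

Measured so far in an assay on isolated protein for binding affinity to Glucagon receptor (Homo sapiens); on this read-out lower numbers stand for stronger inhibition and higher numbers for weaker inhibition:
- compound 1 `CCc1c(C(C)C)nc(C(C)C)c(C(C)O)c1-c1ccc(F)cc1O` gives 16 nM
- compound 2 `CCCc1c(C(C)C)nc(C(C)C)c(C(C)O)c1-c1ccccc1O` gives 25 nM
- compound 3 `CCCc1c(C(C)C)nc(C(C)C)c(C(C)O)c1-c1ccc(F)cc1O` gives 10 nM

Compound 3 has the lowest number of the three. Its separation from compound 1 is small, a 1.6-fold lower number from compound 1 to compound 3 (0.20 log units; within the scatter), whereas the step of a 2.5-fold lower number from compound 2 to compound 3 (0.40 log units; beyond the scatter) is modest but beyond the scatter. Compound 3 therefore cannot be called stronger than compound 1 on this evidence, only stronger than compound 2.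

Compound 4 `CCCCCc1c(C(C)C)nc(C(C)C)c(C(C)O)c1-c1ccc(F)cc1O` differs from compound 3 by ethyl in place of hydrogen on a saturated chain carbon, three bonds along the chain from an aromatic carbon; cut one bond further out, the change reads propyl to pentyl. Of the measured steps, only a 1.6-fold lower number from compound 1 to compound 3 (0.20 log units; within the scatter) bears on it directly: that step lengthened the same chain by one carbon and stayed within the scatter. The fluoro step a 2.5-fold lower number from compound 2 to compound 3 (0.40 log units; beyond the scatter) sits elsewhere and says nothing about chain length. Nothing measured covers an extension by two carbons, so the expectation rests on a single within-scatter step and is correspondingly loose. The expected step is a 1.1-fold lower number from compound 3 to compound 4 (0.05 log units; within the scatter), small and in no reliable direction, most likely within the scatter. Compound 4 is estimated at 9 nM, with a range from 3.5 nM to 25 nM.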

Compound 4, half-maximal inhibitory concentration: 12 nM
Estimate against measurement, compound 4: 1.3-fold (0.12 log units) below; low and high end bracket the measured number.
By their numbers in this assay, from the lowest: compounds 3, 4, 1 and 2 (each within the scatter of the next, the first and the last beyond it).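

In this assay, going from a propyl to a pentyl chain at this position gives a 1.2-fold higher number from compound 3 to compound 4 (0.08 log units; within the scatter), and going from ethyl to pentyl gives a 1.3-fold lower number from compound 1 to compound 4 (0.12 log units; within the scatter), so the longer chain opens no separation from either shorter one. The earlier compounds shown here covered only the ethyl-to-propyl change, a 1.6-fold lower number from compound 1 to compound 3 (0.20 log units; within the scatter); with compound 1, compound 3 and compound 4 together, ethyl, propyl and pentyl all lie within the scatter of one another, and chain length over this range has no readable effect on the number. No measurement at hand explains this flat response to chain length.

Still open, from the compounds shown here alone, is whether the same flat response holds for a longer chain such as heptyl, a branched chain such as isobutyl, a cyclohexyl group, or a chain ending in an amine or a carboxylic acid. Also open, going by these compounds, is how the pentyl chain behaves in the absence of the fluoro group, whose own step is a 2.5-fold lower number from compound 2 to compound 3 (0.40 log units; beyond the scatter).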